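A few compounds are considered here, and "the series" means these few. Any claim that something is new, unique, unknown or untested is made for them only; others in the source may bear on it.

Compound 1 `Brc1cn2ccnc2c(-c2ccc3ncn(C4CCCCC4)c3c2)n1` carries a bromo group on the shared core and in a functional assay on SF-268 cells (Homo sapiens) for inhibition, read by sulforhodamine B assay, with a stated time of 48 h, tested at 10 uM (on this read-out lower numbers stand for less inhibition and higher numbers for more inhibition at the one concentration tested (going by the name of the read-out)), compound 1 gives 17.1%. Compound 2 `CC(=O)c1ccc(-c2cn3ccnc3c(-c3ccc4ncn(C5CCCCC5)c4c3)n2)cc1` replaces that bromo group with a 4-acetylphenyl group, and in this assay compound 2 gives 5.01%, so that a number 12.1 percentage points lower from compound 1 to compound 2 (beyond the scatter). For the measured compounds named here, of the two numbers measured so far, compound 2 stands lowest, with compound 1 as its only neighbour and a number higher by a step beyond the scatter.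

Compound 3 `COc1ccccc1-c1cn2ccnc2c(-c2ccc3ncn(C4CCCCC4)c3c2)n1` is the next member to be measured. Compared with compound 2, (2-methoxyphenyl in place of 4-acetylphenyl on an aromatic carbon). Going by the values given here, the only measured step, a number 12.1 percentage points lower from compound 1 to compound 2 (beyond the scatter), swaps a bromo group for an aryl group and does not exchange one aryl group for another, so no measured step bears directly on this change. A 2-methoxyphenyl group at the same place is expected to remain close to the 4-acetylphenyl group of compound 2, with no step beyond the scatter in this assay, that is a number 4 percentage points higher from compound 2 to compound 3 (within the scatter). The estimated value for compound 3 in this assay is 9%, within -3% to 22%.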

Compound 3, a percentage reported as inhibition, at one concentration (the size of the read-out at that concentration, not a potency): 8.04%
For compound 3 the middle estimate is 1 percentage points above the measured one, within the range that was stated.
By their numbers in this assay, from the lowest: compounds 2, 3 and 1 (each within the scatter of the next, the first and the last beyond it).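

Working from the 4-acetylphenyl group of compound 2, this position now has its first exchange of one aryl group for another: in this assay the step is a number 3 percentage points higher from compound 2 to compound 3 (within the scatter) and so gives no separation between the 2-methoxyphenyl and 4-acetylphenyl groups on this aromatic carbon. The exchange of the bromo group for an aryl group also now has a second reading, a number 9.1 percentage points lower from compound 1 to compound 3 (within the scatter) and thus without the separation seen for the 4-acetylphenyl group in compound 2, so a step beyond the scatter does not hold for every aryl group tried here, with compound 3 going against it. No measurement bears on what lies behind these readings.

From the compounds shown here alone, the three compounds cover only the bromo group and two substituted phenyl groups at this position, so it remains open whether an amine, a carboxylic acid or a longer chain there would stand apart from compound 3 in this assay by more than the scatter. Readings at a single concentration also leave the potency of all three compounds open, as does any change to the cyclohexyl group, which stays the same throughout.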